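This account rests on a few compounds, and the source may have more. Where it says the series, first, only, none or still open, it means among the compounds named here.

Compound 1 `CC(=O)N[C@@H]1CCN(c2cc(C)nn3c(-c4ccc5cc[nH]c5c4)c(C)nc23)C1` — > 95%
Compound 2 `COc1ccc(-c2c(C)nc3c(N4CC[C@@H](NC(=O)c5ccccc5)C4)cc(C)nn23)cc1OC` — > 95%

In an ADME assay on microsomes from liver (Homo sapiens) for metabolic stability, read by LC-MS, with NADPH named in the record, with a stated time of 60 min, tested at 1 uM, in the absence of a further agent (a lower number here means that less of the compound is left, a higher number that more of the compound is left), compound 1 gives > 95%, which is a limit of the assay rather than a measured number. Compound 2 gives > 95% in this assay, again a limit and not a number. Every value shown so far therefore sits at the limit of > 95% in this assay, at which 2 of the 2 values shown sit, so compound 2 stands at the top edge of what this assay can report, with nothing shown lying below it.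

Compound 3 `COc1ccc(-c2c(C)nc3c(N4CC[C@@H](NS(C)(=O)=O)C4)cc(C)nn23)cc1OC` has not yet been measured in this assay. It differs from compound 2 by methylsulfonyl in place of benzoyl on an amine nitrogen. No step between two measured compounds is available, so nothing shown tells how a change of this kind moves the number. Starting from a compound already at the limit, the expected step is none beyond the usual scatter, a number no higher from compound 2 to compound 3 (the limit leaves the size open). Compound 3 is thus estimated at about 95%, between 85% and 99%, with a good chance that the assay once more reports only a limit.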

Compound 3, percent of the compound remaining: > 95%
Compound 3 gave a limit, no number; the forecaster's own chance of this, stated with the estimate: 65%; the middle value sits exactly at the limit.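

Compound 3 gives > 95% in this assay, which is a limit of the assay and not a number. Compound 2 sits at that same limit, so no step from compound 2 to compound 3 can be read: the limit of > 95% in this assay, at which 3 of the 3 values shown sit.

The compounds shown leave open whether methylsulfonyl in place of benzoyl changes how much compound remains at all.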